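The source may hold more compounds than are shown below. What is called first, only, known or untested is meant among the compounds shown, and "the series" means these compounds.

Working notes on the series.

Compound 2 `CC(C)=CCCC1=CC[C@@H](C(=O)Nc2ccc(C(=O)O)cc2)[C@H](c2ccccc2)C1` gives 2200 nM in an assay on isolated protein for inhibition of Apoptosis regulator Bcl-2 (Homo sapiens), read by fluorescence polarization, with stated times of 5 min and 10 min; a lower number here means a stronger inhibitor, a higher number a weaker inhibitor; of the numbers recorded it stands lowest, with compound 1 `CONC(=O)[C@@H]1CC=C(CCC=C(C)C)C[C@H]1c1ccccc1` nearest at 2700 nM. Compound 3 `CC(C)=CCCC1=CC[C@H](C(=O)Nc2ccc(C(=O)O)cc2)[C@@H](c2ccccc2)C1` returns only a limit of the assay, > 23000 nM, and not a number. The step of a 1.2-fold lower number from compound 1 to compound 2 (0.09 log units; within the scatter) shows that 4-carboxyphenyl in place of methoxy on an amide-type nitrogen leaves the number where it was. The step of an at least 10-fold higher number from compound 2 to compound 3 (1.01 log units; beyond the scatter) is the one large effect seen, and it rests on the fact that compounds 2 and 3 differ only in the configuration as drawn together with the limit of > 23000 nM in this assay, at which 1 of the 3 values shown sits.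

Compound 4 `CC(C)=CCCC1=CC[C@@H](C(=O)N(C)O)[C@H](c2ccccc2)C1` keeps the configuration of compound 2 and changes only the amide end: hydroxy(methyl)amino in place of (4-carboxyphenyl)amino on a carbonyl carbon. For the measured compounds named here, the step that bears on this is the one from compound 1 to compound 2, which was within the scatter, so a small group on the amide nitrogen and the carboxyphenyl group are read as interchangeable here. No step beyond the scatter is expected in this assay for a 1.2-fold higher number from compound 2 to compound 4 (0.07 log units; within the scatter). Compound 4 is therefore estimated at 2600 nM, with a range of 1000 nM to 7000 nM.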

Compound 4, inhibition constant: 2300 nM
Beside the measured number, compound 4's estimate is 1.1-fold (0.05 log units) above it, within the range that was stated.
By their numbers in this assay, from the lowest: compounds 2, 4 and 1 (each within the scatter of the next). At a limit, above all of these: compound 3.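

In this assay, the new step of a 1.0-fold higher number from compound 2 to compound 4 (0.02 log units; within the scatter) shows that the whole (4-carboxyphenyl)amino group, with its aromatic ring and carboxyl group, can give way to hydroxy(methyl)amino on this carbonyl carbon without a change beyond the scatter. The second new step, a 1.2-fold lower number from compound 1 to compound 4 (0.07 log units; within the scatter), adds that moving the methyl and the oxygen-borne group around the amide nitrogen, from methoxyamino to hydroxy(methyl)amino, also stays within the scatter, so compounds 1, 2 and 4 form a flat set for this position. The measured data give no cause for this flatness.

As far as these compounds go, whether a carboxylic acid or a piperidine amide on this carbonyl carbon would produce a step beyond the scatter remains open. So does whether the configuration matters as much with hydroxy(methyl)amino as it does with (4-carboxyphenyl)amino.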